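The compounds below may be only part of what the source reports. "The series", "measured", "known", "first", "only" and "open" are said of these compounds alone.

Compound 1 `CS(=O)(=O)Nc1cccc2c1CCC2c1ncc[nH]1` carries a methanesulfonamido group on its core. In a functional assay on CHO cells for agonist activity at Alpha-1D adrenergic receptor (Homo sapiens), read by FLIPR and calcium flux (a higher number here means that more compound is needed for the effect, a lower number that less compound is needed), compound 1 gives only a limit, > 10000 nM. Compound 2 `Cc1c(OCC2=NCCN2)ccc(Cl)c1NS(C)(=O)=O` also reaches only a limit in this assay, > 10000 nM. Compound 3 `Clc1ccc2c(c1-c1ccn[nH]1)CCC2c1ncc[nH]1` likewise gives a limit, > 10000 nM. So compound 1 sits where all three measured compounds sit, at the limit of > 10000 nM in this assay, at which 3 of the 3 values shown sit, and no measured pair shows a finished step for comparison.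

Compound 4 `Cn1cc(-c2cccc3c2CCC3c2ncc[nH]2)cn1` differs from compound 1 by one change: 1-methyl-1H-pyrazol-4-yl in place of methanesulfonamido on an aromatic carbon. With every measured value at the limit, the expected step from compound 1 to compound 4 is a step that the limit leaves unreadable from compound 1 to compound 4, meaning none that can be told from a limit. Compound 4 is therefore estimated at 15000 nM, most likely again only a limit, within a range from 3000 nM to 100000 nM.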

Compound 4, half-maximal effective concentration: > 10000 nM
Compound 4: no number, only a limit; the forecaster's own chance of this, stated with the estimate: 75%; the middle value is on the limit's open side.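

Compound 1 and compound 4 each give only a limit, so no step can be read between them: the limit of > 10000 nM in this assay, at which 4 of the 4 values shown sit. The compounds shown leave open whether methanesulfonamido and 1-methyl-1H-pyrazol-4-yl differ at all in this assay, and which compound would give a readable value there.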